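Swapping the Aryl Group of Compound 2

A few compounds are considered here, and "the series" means these few. Any claim that something is new, unique, unknown or untested is made for them only; others in the source may bear on it.

Of the compounds shown here, two with a shared core have been tested in a functional assay on MCF7 cells (Homo sapiens) for inhibition, read by MTT assay, with a stated time of 48 h, tested at 10 uM; on this read-out higher numbers stand for more inhibition of growth at the one concentration tested and lower numbers for less inhibition of growth. Compound 1, `Cc1cc(=O)c2c(O)c(CN3CCCCC3)c(O)c([C@H]3CCN(C)C[C@H]3O)c2o1`, gives 15% in this assay. Compound 2, `Cc1oc2c([C@H]3CCN(C)C[C@H]3O)c(O)cc(O)c2c(=O)c1C(O)c1ccc([N+](=O)[O-])cc1`, gives 4% in this assay, the lowest of the two numbers; compound 1 is the nearer of the two, and the gap between them lies beyond the usual scatter of repeated measurements.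

Compound 3, `Cc1oc2c([C@H]3CCN(C)C[C@H]3O)c(O)cc(O)c2c(=O)c1C(O)c1cccc(Cl)c1Cl`, has not yet been measured in this assay. It differs from compound 2 in one place: 2,3-dichlorophenyl in place of 4-nitrophenyl on a saturated chain carbon bound to an aromatic carbon and an oxygen on a saturated carbon. Within the data shown here, no measured pair shows the same change, so its size cannot be read from the data; the only guide is that compound 2 itself sits at a low value in this assay.

Compound 3 is therefore expected to stay near the low end, with a step from compound 2 of about a number 6 percentage points higher from compound 2 to compound 3 (within the scatter), likely within the scatter or a little upward. The estimate for compound 3 in this assay is 10%, in a range from -5% to 30%.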

Compound 3, percent growth inhibition at one concentration: 7%
Beside the measured number, compound 3's estimate is 3 percentage points above it; low and high end bracket the measured number.
By their numbers in this assay, from the lowest: compounds 2, 3 and 1 (each within the scatter of the next, the first and the last beyond it).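

In this assay, among these compounds, the exchange of 4-nitrophenyl for 2,3-dichlorophenyl on a saturated chain carbon bound to an aromatic carbon and an oxygen on a saturated carbon gives a number 3 percentage points higher from compound 2 to compound 3 (within the scatter), the first step that can be read at this position. It shows that this assay does not separate these two aryl groups, even though 4-nitrophenyl carries hydrogen-bond acceptors and 2,3-dichlorophenyl carries none, so for this one pair that difference comes with no step beyond the scatter. No supporting data are available to explain this result.

As far as these compounds go, a single pair cannot show whether the position responds to other groups, and it remains open what an aminomethyl or a carboxylic acid on the phenyl ring, or a longer chain between the hydroxy-bearing carbon and the ring, would do to growth inhibition. It is equally open whether the hydroxy group on this carbon matters, and whether a plain phenyl ring without any substituent would read the same as the two aryl groups shown here.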